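Thiazolyl for furanyl: solubility outlook for compound 3

The compounds below may be only part of what the source reports. "The series", "measured", "known", "first", "only" and "open" are said of these compounds alone.

In a physicochemical assay for solubility, at pH 6 (a lower number here means a less soluble compound, a higher number a more soluble compound), compound 1 `NC(=O)c1ccc(-c2cc(-c3ccc([N+](=O)[O-])cc3)nc(-c3ccco3)c2)cc1` gives 8000 nM. Compound 2 `N#Cc1ccc(-c2cc(-c3ccc(C(N)=O)cc3)cc(-c3ccco3)n2)cc1` gives 10000 nM in this assay. For the measured compounds named here, the only measured step, a 1.3-fold higher number from compound 1 to compound 2 (0.10 log units; within the scatter), separates the two; compound 2 therefore stands alongside compound 1 within the scatter, and no ordering of the pair can be claimed from these two numbers.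

Compound 3 `N#Cc1ccc(-c2cc(-c3ccc(C(N)=O)cc3)cc(-c3cncs3)n2)cc1` differs from compound 2 by 1,3-thiazol-5-yl in place of furan-2-yl on an aromatic carbon. Going by the values given here, none of the measured steps touches this position: the step from compound 1 to compound 2 concerns the cyano and nitro substituents elsewhere in the molecule and was within the scatter. Among the compounds with values here, there is thus no direct precedent for a furanyl-to-thiazolyl exchange, and the one step available shows the series tolerating a single-group swap without a shift in this assay beyond the scatter.

The expectation for compound 3 is accordingly a step of about a 1.2-fold higher number from compound 2 to compound 3 (0.08 log units; within the scatter), that is, no change beyond the scatter. Compound 3 is estimated at 12000 nM in this assay, with a range from 5000 nM to 30000 nM.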

Compound 3, solubility: 64000 nM
Compound 3: the middle estimate sits 5.3-fold (0.73 log units) below what was measured; measured number outside the range, above it.
By their numbers in this assay, from the lowest: compounds 1 and 2 (each within the scatter of the next); then compound 3.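

In this assay, the position next to the ring nitrogen shows what the earlier cyano and nitro exchange did not: a single-group exchange in this series can give a step beyond the scatter, with 1,3-thiazol-5-yl in place of furan-2-yl giving a 6.4-fold higher number from compound 2 to compound 3 (0.81 log units; beyond the scatter). The heavy-atom count stays at 5 on both sides and neither group has a hydrogen-bond donor, so the step comes with a change in ring atoms and acceptor count: furan-2-yl has 1 hetero atom and 1 hydrogen-bond acceptor, whereas 1,3-thiazol-5-yl has 2 of each. Nothing on hand gives a measured reason for this step.

With only this one exchange at the position, the compounds shown do not separate the contributions of the ring nitrogen, the sulfur and the point of attachment, which a 1,3-thiazol-2-yl or thiophen-2-yl group would help to resolve. Also open, on these data alone, are how an amine or a carboxylic acid at this position would read in this assay and whether the step carries over to the nitro partner of compound 1.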